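This account rests on a few compounds, and the source may have more. Where it says the series, first, only, none or still open, it means among the compounds named here.

Measured so far in a functional assay on DLD-1 cells (Homo sapiens) for cytotoxicity, with a stated time of 48 h; a lower number here means a stronger inhibitor, a higher number a weaker inhibitor:
- compound 1 `CC(C)C(=O)Oc1ccc2oc(/C=C/[S+](C)[O-])cc(=O)c2c1` gives 9100 nM
- compound 2 `CCCOc1ccc2oc(/C=C/[S+](C)[O-])cc(=O)c2c1` gives 6200 nM
- compound 3 `COc1ccc2oc(/C=C/[S+](C)[O-])cc(=O)c2c1` gives 5700 nM

Compound 3 stands within the scatter of both other compounds (a 1.6-fold lower number from compound 1 to compound 3 (0.20 log units; within the scatter) and a 1.1-fold lower number from compound 2 to compound 3 (0.04 log units; within the scatter)). The change to compound 4 `CC(C)Oc1ccc2oc(/C=C/[S+](C)[O-])cc(=O)c2c1` is isopropyl in place of methyl on an oxygen on an aromatic ring. The closest evidence is the swap between propyl and methyl on that oxygen (a 1.1-fold lower number from compound 2 to compound 3 (0.04 log units; within the scatter)). The swap of isopropylcarbonyl for propyl also stayed within the scatter (a 1.5-fold lower number from compound 1 to compound 2 (0.17 log units; within the scatter)). No step beyond the scatter, in either direction, is therefore expected in this assay (a 1.1-fold higher number from compound 3 to compound 4 (0.04 log units; within the scatter)). Compound 4 is estimated at 6200 nM (expected range 3500 nM to 11000 nM).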

Compound 4, half-maximal inhibitory concentration: 8000 nM
Compound 4: middle estimate off by 1.3-fold (0.11 log units), on the low side; measured number inside the range.
By their numbers in this assay, from the lowest: compounds 3, 2, 4 and 1 (each within the scatter of the next).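

On the oxygen on the aromatic ring, a branched group gives no step beyond the scatter in this assay against either straight ether: methyl to isopropyl (a 1.4-fold higher number from compound 3 to compound 4 (0.15 log units; within the scatter)) and propyl to isopropyl (a 1.3-fold higher number from compound 2 to compound 4 (0.11 log units; within the scatter)). Isopropyl in place of isopropylcarbonyl also stays within the scatter (a 1.1-fold lower number from compound 1 to compound 4 (0.06 log units; within the scatter)), so all four groups at this oxygen now lie within the scatter of one another. No measurement at hand bears on why these steps are so small.

Going by these compounds, whether a longer chain, an amine or a carboxylic acid at this oxygen would give a step beyond the scatter remains open.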